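The source may hold more compounds than are shown below. What is called first, only, known or untested is meant among the compounds shown, and "the series" means these compounds.

Measured compounds:
compound 1 `O=C(NCC(=O)N1[C@@H](c2cccc(O)c2)CC[C@H]1C(=O)O)[C@@H](S)Cc1ccccc1`: 2.4 nM
compound 2 `Cc1ccccc1[C@H]1CC[C@@H](C(=O)O)N1C(=O)CNC(=O)[C@@H](S)Cc1ccccc1`: 5.3 nM

In an assay on isolated protein for inhibition of Neprilysin (Oryctolagus cuniculus) (a lower number here means a stronger inhibitor, a higher number a weaker inhibitor), compound 1 gives 2.4 nM, the lower of the two numbers recorded. Within the data shown here, compound 2 gives 5.3 nM, and the only measured step, a 2.2-fold higher number from compound 1 to compound 2 (0.34 log units; beyond the scatter), changes the aromatic group on the saturated ring, not the part of the molecule in question here.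

Compound 3 `O=C(NCC(=O)N1[C@@H](c2cccc(O)c2)CC[C@H]1C(=O)O)[C@@H](S)Cc1ccc(O)cc1` differs from compound 1 by hydroxy in place of hydrogen on an aromatic carbon, para to a large group, turning the benzyl into a 4-hydroxybenzyl. Among the measured compounds shown here, no measured step touches this benzyl, so nothing recorded bears directly on it; the one measured step elsewhere was modest.

With no guide for this change, compound 3 is expected to stay close to compound 1, with a step of a 1.3-fold higher number from compound 1 to compound 3 (0.10 log units; within the scatter) that may well lie within the scatter. The estimate for compound 3 is 3 nM, within a range of 1 nM to 9 nM.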

Compound 3, half-maximal inhibitory concentration: 1.6 nM
Beside the measured number, compound 3's estimate is 1.9-fold (0.27 log units) above it; low and high end bracket the measured number.
By their numbers in this assay, from the lowest: compounds 3 and 1 (each within the scatter of the next); then compound 2.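

In this assay, turning the benzyl of compound 1 into the 4-hydroxybenzyl of compound 3 gives a 1.5-fold lower number from compound 1 to compound 3 (0.18 log units; within the scatter), so this assay cannot tell the two compounds apart. Among these compounds, this is the first reading at this position, and it shows that a hydroxy group can sit on this aromatic ring, para to a large group, with no difference beyond the scatter. Nothing available accounts for this result.

One hydroxy group says little about other groups at the same place, so an amine, a carboxylic acid or a methoxy group could give quite different numbers. From the compounds shown here alone, it also remains open whether hydroxy would give a similar result on compound 2, which has 2-methylphenyl in place of 3-hydroxyphenyl on the saturated ring.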